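A few compounds are considered here, and "the series" means these few. Any claim that something is new, unique, unknown or untested is made for them only; others in the source may bear on it.

Measured so far in an ADME assay on HepG2 2.2.15 cells (Homo sapiens) for cytotoxicity; on this read-out higher numbers stand for lower toxicity in this test and lower numbers for higher toxicity in this test:
compound 1 `O=C(Nc1ncc(Cc2ccc(F)cc2)s1)c1ccc(Br)cc1`: > 50000 nM
compound 2 `CC(C)(C)OC(=O)Nc1ncc(C(Oc2cccc(C#N)c2)c2ccc(Cl)cc2)s1`: > 50000 nM
compound 3 `O=C(Nc1ncc(C(Oc2ccc3cc(Br)ccc3c2)c2ccc(Cl)cc2)s1)C1CC1`: "not toxic" (no number reported)

The value of compound 1 is a limit of this assay, not a number. The value of compound 2 is likewise a limit of this assay. Compound 3 gives no number at all in this assay and is recorded only as not toxic, so it stands among the non-toxic entries of the series, in line with the limit of > 50000 nM in this assay, at which 2 of the 3 values shown sit, where most of the shown values sit. For the measured compounds named here, no pair of measured compounds differs in only one place, so no measured step and no spread between steps is available for this assay.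

Compound 4 `O=S(=O)(Nc1ncc(C(Oc2ccc3cc(Br)ccc3c2)c2ccc(Cl)cc2)s1)c1ccc(Cl)nc1` is the next compound to be measured in this assay. It differs from compound 3 as follows: (6-chloropyridin-3-yl)sulfonyl in place of cyclopropylcarbonyl on a nitrogen on an aromatic ring.

Going by the values given here, with no measured step to lean on, the expectation for this change rests on the standing of compound 3 alone: no shift beyond the usual scatter is expected, and compound 4 is expected to be reported as a limit again or as a number close to it. Compound 4 is expected to give about 50000 nM in this assay, within a range from 20000 nM to 100000 nM.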

Compound 4, half-maximal cytotoxic concentration: "not toxic" (no number reported)
Nothing numeric was reported for compound 4, and the estimate cannot be compared.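

Compound 3 and compound 4 are both recorded in this assay only as not toxic, with no number, so no step can be read between them. The compounds shown leave open at what concentration any of them would become cytotoxic, as the only figure reported is a limit: the limit of > 50000 nM in this assay, at which 2 of the 4 values shown sit.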